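This account rests on a few compounds, and the source may have more. Where it says the series, first, only, none or still open, it means among the compounds named here.

Measured so far:
compound 1 `CC1CCCC(C(=O)N2CC(c3nc(-c4cccc(Cl)c4)no3)C2)C1` — > 10000 nM
compound 2 `O=C(C1CCCO1)N1CC(c2nc(-c3cccc(Cl)c3)no2)C1` — 890 nM
compound 3 `O=C(c1ccc(F)c(F)c1)N1CC(c2nc(-c3cccc(F)c3)no2)C1` — > 10000 nM

Going by the values given here, in an assay on HEK293 cells for negative allosteric modulation of metabotropic glutamate receptor 5 (Homo sapiens), read by FLIPR (on this read-out higher numbers stand for weaker inhibition and lower numbers for stronger inhibition), compound 2 holds the only number; the other two values are limits. Compound 1 sits at a limit, > 10000 nM. Compound 3 also sits at a limit, > 10000 nM. This is noted as the limit of > 10000 nM in this assay, at which 2 of the 3 values shown sit.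

Compound 4 `O=C(N1CCCCCC1)N1CC(c2nc(-c3cccc(Cl)c3)no2)C1` is not yet measured. It differs from compound 2 by azepan-1-yl in place of oxolan-2-yl on a carbonyl carbon. Among the compounds with values here, the one step that bears on the carbonyl substituent is an at least 11-fold lower number from compound 1 to compound 2 (1.05 log units; beyond the scatter), where a cyclic ether ring replaced an all-carbon ring and gave a large gain. The change to compound 4 goes the other way: the ring oxygen acceptor leaves and a larger carbon-rich ring enters.

Compound 4 is therefore expected to give a weaker value, with a step of a 5.6-fold higher number from compound 2 to compound 4 (0.75 log units; beyond the scatter). The estimate for compound 4 is 5000 nM, within 1500 nM to 20000 nM.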

Compound 4, half-maximal inhibitory concentration: > 10000 nM
Compound 4: no number, only a limit (the forecaster's own chance of this, stated with the estimate: 40%); at least 2.0-fold (0.30 log units) between middle value and limit.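

In this assay, the gain seen with oxolan-2-yl does not carry over to a nitrogen-linked ring on this carbonyl carbon: an at least 11-fold higher number from compound 2 to compound 4 (1.05 log units; beyond the scatter). Compound 1 alone could not show this, as its 3-methylcyclohexyl is carbon-linked, and the step from compound 1 to compound 4 cannot be read, both values being limits. Compound 4 also stands at a limit, not a number: the limit of > 10000 nM in this assay, at which 3 of the 4 values shown sit.

Open, going by these compounds, is whether the ring oxygen or the ring size separates compound 2 from compound 4. Morpholin-4-yl, pyrrolidin-1-yl or oxan-2-yl on the same carbonyl carbon would bear on this.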